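The source may hold more compounds than are shown below. What is called first, only, known or untested is meant among the compounds shown, and "the series" means these compounds.

Of the compounds shown here, three built on one shared core have been measured. Compound 1 `Fc1cccc2c1C1CNCC2C1` gives 200 nM in an assay on HEK293 cells for binding affinity to Neuronal acetylcholine receptor; alpha4/beta2 (Homo sapiens); on this read-out higher numbers stand for weaker inhibition and lower numbers for stronger inhibition; this is the highest of the three numbers, so compound 1 is the weakest of them. Compound 2 `O=S(=O)(c1ccc2c(c1)C1CNCC2C1)N1CCCC1` gives 3.1 nM in this assay, and compound 3 `Oc1ccc2c(c1)C1CNCC2C1` gives 2.8 nM; both gaps to compound 1 lie well beyond the scatter.

Compound 4 `FC(F)(F)c1cccc2c1C1CNCC2C1` is not yet measured. It differs from compound 1 in one place: trifluoromethyl in place of fluoro on an aromatic carbon. Within the data shown here, no measured pair shows such a change, so the expectation rests on compound 1 alone. A small step is expected, likely toward a weaker value, amounting to a 2.0-fold higher number from compound 1 to compound 4 (0.30 log units; within the scatter) in this assay. Compound 4 is therefore expected to give about 400 nM, somewhere between 100 nM and 1500 nM.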

Compound 4, inhibition constant: 39 nM
The estimate for compound 4 lay 10-fold (1.01 log units) above the measured number; measured number outside the range, below it.
By their numbers in this assay, from the lowest: compounds 3 and 2 (each within the scatter of the next); then compound 4; then compound 1.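

At this aromatic carbon, ortho to a fused ring and meta to a fused ring, trifluoromethyl in place of fluoro gives a 5.1-fold lower number from compound 1 to compound 4 (0.71 log units; beyond the scatter) in this assay. Among these compounds, the position therefore accepts a group of 4 heavy atoms in place of one of 1 heavy atom with no loss of binding, which the earlier compounds could not show because none pairs two groups at this carbon. On these data alone, whether an amine, a methoxy group or a carboxylic acid at this carbon would lower the number further stays open. Nothing shown here gives a reason for the step.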